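Compound 1 to compound 4: exchange of the aryl group

This account rests on a few compounds, and the source may have more. Where it says the series, first, only, none or still open, it means among the compounds named here.

In a functional assay on A549 cells (Homo sapiens) for inhibition, read by MTT assay, with a stated time of 72 h (a lower number here means a stronger inhibitor, a higher number a weaker inhibitor), compound 1 (`CC1=NN(c2ccccc2)C(=O)[C@]12C(=O)C=CC[C@H]2c1ccc(C)cc1`) gives 2890 nM and holds the lowest of the three numbers. Its mirror image, compound 2 (`CC1=NN(c2ccccc2)C(=O)[C@@]12C(=O)C=CC[C@@H]2c1ccc(C)cc1`), gives 6570 nM in the same test, and compound 3 (`CC1=NN(c2ccccc2)C(=O)[C@]12C(=O)C=CC[C@@H]2c1ccc(C)cc1`), with one stereocentre inverted, gives 8600 nM in the same test. The steps of a 2.3-fold higher number from compound 1 to compound 2 (0.36 log units; beyond the scatter) and a 3.0-fold higher number from compound 1 to compound 3 (0.47 log units; beyond the scatter) are modest and beyond the scatter, whereas a 1.3-fold higher number from compound 2 to compound 3 (0.12 log units; within the scatter) stays within it.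

Compound 4 (`COc1ccccc1[C@@H]1CC=CC(=O)[C@]12C(=O)N(c1ccccc1)N=C2C`) carries 2-methoxyphenyl in place of 4-methylphenyl on a saturated ring carbon of the core of compound 1. Among the measured compounds shown here, no measured step changes this group, so the three steps give only a rough scale, and that scale is modest. For the measured compounds named here, with compound 1 at 2890 nM as the lowest number so far, a modest upward move is expected rather than a further gain. The expected step is a 1.7-fold higher number from compound 1 to compound 4 (0.24 log units; within the scatter) and carries wide uncertainty. Compound 4 is estimated at 5000 nM with an expected range of 1800 nM to 14000 nM in this assay on present data.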

Compound 4, half-maximal inhibitory concentration: 3960 nM
Estimate against measurement, compound 4: 1.3-fold (0.10 log units) above; the range from low to high includes it.
By their numbers in this assay, from the lowest: compounds 1, 4, 2 and 3 (each within the scatter of the next, the first and the last beyond it).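

In this assay, among the compounds shown here, the first exchange of the group itself on this saturated ring carbon, 2-methoxyphenyl in place of 4-methylphenyl, stays within the scatter: a 1.4-fold higher number from compound 1 to compound 4 (0.14 log units; within the scatter). For the compounds shown here, the earlier compounds varied only configuration on the shared core, so this is the first reading for the position: an aryl group that carries an oxygen and lacks the 4-methyl is accepted here at a number not separable from that of compound 1. No measured property of either aryl group is at hand to account for this reading.

The compounds shown leave open whether the configuration steps seen with 4-methylphenyl carry over to 2-methoxyphenyl. They also leave open how this position answers to an aryl group bearing an amine or a carboxylic acid.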